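Phenyl Replaces Nitro on the Aryl Ether Ring

The source may report more compounds than this note shows. Statements on the series, on what has been measured and on what is new or still open speak of the compounds shown alone.

Measured so far:
- compound 1, `N#Cc1ccc(Cn2cc(COc3ccc(Cl)cc3)nn2)cc1`: 3910 nM
- compound 2, `N#Cc1ccc(Cn2cc(COc3ccc([N+](=O)[O-])cc3)nn2)cc1`: 5620 nM

Both compounds were tested in an assay on isolated protein for inhibition of Aromatase (Homo sapiens), read by fluorescence and colorimetric assay, with a stated time of 30 min; a higher number here means a weaker inhibitor, a lower number a stronger inhibitor. Compound 1 gives 3910 nM and compound 2 gives 5620 nM. Going by the values given here, the one step between them, a 1.4-fold higher number from compound 1 to compound 2 (0.16 log units; within the scatter), is too small to separate the two, so compound 2 cannot be called weaker or stronger than compound 1; it simply holds the higher of the two numbers, with compound 1 nearest.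

Compound 3, `N#Cc1ccc(Cn2cc(COc3ccc(-c4ccccc4)cc3)nn2)cc1`, has not been measured. It differs from compound 2 in one place: phenyl in place of nitro on an aromatic carbon, on an aromatic carbon para to a large group.

Among the compounds with values here, only the step from compound 1 to compound 2 touches this position, and it changed the number by a 1.4-fold higher number from compound 1 to compound 2 (0.16 log units; within the scatter), within the scatter. That step swapped one small group for another; nothing measured shows what a phenyl does there. With that thin basis, compound 3 is expected to land near compound 2, a change of a 1.2-fold lower number from compound 2 to compound 3 (0.10 log units; within the scatter) at most, with a wide range to reflect the lack of guidance. The estimate for compound 3 in this assay is 4500 nM, between 1200 nM and 17000 nM.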

Compound 3, half-maximal inhibitory concentration: 11600 nM
Compound 3: middle estimate off by 2.6-fold (0.41 log units), on the low side; the measured number falls inside the stated range.
By their numbers in this assay, from the lowest: compounds 1 and 2 (each within the scatter of the next); then compound 3.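

Chloro and nitro gave numbers that could not be told apart, so this position could have seemed indifferent to what sits on it, but in this assay phenyl shows otherwise: in place of nitro it gives a 2.1-fold higher number from compound 2 to compound 3 (0.31 log units; beyond the scatter) and in place of chloro it gives a 3.0-fold higher number from compound 1 to compound 3 (0.47 log units; beyond the scatter) on the same aromatic carbon. Compound 3 is therefore the weakest inhibitor of the three, yet the steps are modest, so a whole aromatic ring of six heavy atoms, where nitro has three, costs some inhibition here without abolishing it. Nothing available explains why this change raises the number.

As far as these compounds go, whether the loss comes from the aromatic ring itself or simply from the number of atoms added stays open, and a cyclohexyl group or a longer chain at this carbon would help separate the two. Also open, from the compounds shown here alone, is how an amine or a carboxylic acid would compare here, and whether any group at this position can bring the number clearly below those of compound 1 and compound 2.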